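The source may report more compounds than this note shows. Statements on the series, on what has been measured and on what is new or still open speak of the compounds shown alone.

Three esters of one shared core have been measured in a functional assay on HBL-100 cells (Homo sapiens) for inhibition, read by sulforhodamine B assay, with a stated time of 48 h; on this read-out higher numbers stand for weaker inhibition of growth and lower numbers for stronger inhibition of growth. Compound 1 `O=C(CCCCCc1ccccc1)OCC1COCCOCCOCCOCCOCCO1` gives 64000 nM in this assay. Compound 2 `CC(C)=CC1C(C(=O)OCC2COCCOCCOCCOCCOCCO2)C1(C)C` gives 40000 nM, and the step of a 1.6-fold lower number from compound 1 to compound 2 (0.20 log units; within the scatter) stays within the scatter. For compound 3 `O=C(CCCCOc1ccccc1)OCC1COCCOCCOCCOCCOCCO1` the assay reports only a limit of > 100000 nM and not a number. That limit is the limit of > 100000 nM in this assay, at which 1 of the 3 values shown sits, so the steps of an at least 1.5-fold higher number from compound 1 to compound 3 (0.19 log units; that floor lies within the scatter) and an at least 2.5-fold higher number from compound 2 to compound 3 (0.39 log units; beyond the scatter) carry only floors, and all three measured compounds sit at the weak end of the read-out.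

Compound 4 `O=C(OCC1COCCOCCOCCOCCOCCO1)c1cccnc1` differs from compound 3 by a single change, namely pyridin-3-yl in place of 4-phenoxybutyl on a carbonyl carbon as computed from the two structures. Within the data shown here, the steps that bear on it are the two earlier swaps of the group on the carbonyl carbon, a 1.6-fold lower number from compound 1 to compound 2 (0.20 log units; within the scatter) within the scatter and an at least 2.5-fold higher number from compound 2 to compound 3 (0.39 log units; beyond the scatter) at least modest. Such swaps have moved the numbers little, and nothing among the measured compounds points to a strong gain. Compound 4 is therefore expected to remain weak, with a fair chance that only a limit is reported again. The step is expected to be a number no higher from compound 3 to compound 4 (the limit leaves the size open). The estimate for compound 4 is 100000 nM, between 40000 nM and 250000 nM.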

Compound 4, concentration for 50% growth inhibition: > 100000 nM
Compound 4: only a limit was reported; the forecaster's own chance of this, stated with the estimate: 60%; the middle value lies on the limit itself.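

A ring alone, pyridin-3-yl, in place of a chain on the carbonyl carbon does not bring the shared core to a readable number in this assay, and the result stays at a limit, the same one reached by 4-phenoxybutyl: the limit of > 100000 nM in this assay, at which 2 of the 4 values shown sit.

Set against the cyclopropyl ester, the change gives an at least 2.5-fold higher number from compound 2 to compound 4 (0.39 log units; beyond the scatter), so compound 4 is clearly weaker than compound 2, while the comparison with the 5-phenylpentyl ester gives an at least 1.5-fold higher number from compound 1 to compound 4 (0.19 log units; that floor lies within the scatter), which does not separate the pair beyond the scatter. Compound 3 and compound 4 both stand at a limit, so the step that joins them cannot be read and neither group can be ranked above the other.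

The compounds shown leave open how far past the limit compound 3 and compound 4 really lie, and whether any group on the carbonyl carbon can give clearly stronger inhibition of growth than compound 2 does. An amine or a carboxylic acid at the end of a longer chain on that carbonyl carbon would be one way to probe this.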